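Cyano in place of hydrogen: compound 1 to compound 3

A few compounds are considered here, and "the series" means these few. Any claim that something is new, unique, unknown or untested is made for them only; others in the source may bear on it.

For the measured compounds named here, compound 1 `CCN(C(=O)c1cnc(-c2ccccc2C)cn1)c1ccc(OC)nc1` is the only member of this small set with a result in a functional assay on cells for antagonist activity at Vasopressin V2 receptor (Homo sapiens), read by a beta-lactamase reporter; a higher number here means a weaker inhibitor, a lower number a stronger inhibitor. In this assay compound 1 gives > 10000 nM, which is a limit of the assay and not a number. Compound 1 therefore stands at the limit of > 10000 nM in this assay, at which 1 of the 2 values shown sits, and nothing narrower can be said about it. Compound 2 `COc1ccc(N(C)C(=O)c2cnc(-c3ccc(F)cc3C)cn2)cn1` was also examined; in this assay compound 2 gives "not determined" (no result reported), so it contributes no number either. Going by the values given here, no step between two measured compounds exists in this set, and no comparison can be drawn from it.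

Compound 3 `CCN(C(=O)c1cnc(-c2ccc(C#N)cc2C)cn1)c1ccc(OC)nc1` differs from compound 1 by cyano in place of hydrogen on an aromatic carbon. With compound 1 known only as a limit, the step from compound 1 to compound 3 an at least 1.1-fold lower number from compound 1 to compound 3 (0.04 log units; that floor lies within the scatter) in this assay is expected to be none beyond the scatter, in either direction, as an expectation only. Compound 3 is expected to give 9000 nM in this assay, within 2500 nM to 30000 nM.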

Compound 3, inhibition constant: > 10000 nM
Compound 3: a limit, no number (the forecaster's own chance of this, stated with the estimate: 60%); at least 1.1-fold (0.04 log units) between middle value and limit.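

In this assay compound 3 gives > 10000 nM, which is a limit of the assay and not a number. Compound 1 is also known only as a limit, so no step from compound 1 to compound 3 can be read: the limit of > 10000 nM in this assay, at which 2 of the 3 values shown sit.

As far as these compounds go, whether cyano in place of hydrogen on an aromatic carbon changes the result in this assay remains open.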